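The compounds below may be only part of what the source reports. "The series", "measured", "known", "first", "only" and "open" are said of these compounds alone.

Of the compounds shown here, three share one core and have been tested in a functional assay on A-375 cells (Homo sapiens) for antiproliferative activity, read by CCK-8 assay, with a stated time of 72 h, tested at 8 uM; a lower number here means a weaker effect, a higher number a stronger effect of the compound at the concentration tested. Among the measured compounds shown here, compound 1 `CC1CCCCN1C(=S)SCc1ccc(C(=O)Nc2ccccc2N)cc1` gives 85.2% and compound 3 `CN(C(=S)SCc1ccc(C(=O)Nc2ccccc2N)cc1)c1cccnc1` gives 87.7%; the only single-point step between measured compounds, a number 2.5 percentage points higher from compound 1 to compound 3 (within the scatter), lies within the scatter. Compound 2 `COc1ccc(N2CCN(C(=S)SCc3ccc(C(=O)Nc4ccccc4N)cc3)CC2)cc1` gives 35.9%, the lowest of the three numbers, and its distance to each of the other two is beyond the scatter.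

Compound 4 `N#Cc1ccc(N2CCN(C(=S)SCc3ccc(C(=O)Nc4ccccc4N)cc3)CC2)cc1` differs from compound 2 in one place: cyano in place of methoxy on an aromatic carbon. For the measured compounds named here, no measured step touches this part of the molecule. Going by the values given here, the one step that was measured exchanges the whole group on the thiocarbonyl carbon and is itself within the scatter, so it does not bear on a change of a small substituent on a six-membered aromatic ring further out. Among the compounds with values here, what the numbers show is only that compound 2 is the weak member of the set; nothing measured says whether the cyano moves the number up or down from there. The expected step is therefore a number 4.1 percentage points higher from compound 2 to compound 4 (within the scatter), a change that is not expected to go beyond the scatter. Compound 4 is estimated at 40%, with a range from 18% to 65%.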

Compound 4, a percentage reported as inhibition, at one concentration (the size of the read-out at that concentration, not a potency): 62.9%
Estimate against measurement, compound 4: 22.9 percentage points below, and the stated range covers the measured number.
By their numbers in this assay, from the lowest: compound 2; then compound 4; then compounds 1 and 3 (each within the scatter of the next).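

In this assay the exchange of methoxy for cyano gives a number 27 percentage points higher from compound 2 to compound 4 (beyond the scatter) and so shows that this aromatic carbon, para to a large group, is a place where a small substituent can change the read-out. Among the compounds shown here, the only earlier step exchanged the whole group on the thiocarbonyl carbon and stayed within the scatter, whereas here two groups with the same heavy-atom count, one hydrogen-bond acceptor each, no ring and no net charge give a step beyond it, so those counts alone do not set the number. Nothing available explains why the step runs in this direction.

The compounds shown hold only methoxy and cyano at this place, so it remains open where an amine, a carboxylic acid or a fluorine atom there would fall relative to these two. They also do not tell whether the cyano would give a step of this size from another carbon of the same ring.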